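From Bromomethyl to 1-Bromoethyl: an Expected Step

The source may hold more compounds than are shown below. What is called first, only, known or untested is meant among the compounds shown, and "the series" means these compounds.

compound 1 `O=C(CBr)Nc1ccc(C(=O)/C=C/c2ccc(Cl)cc2)cc1`: 59%
compound 2 `COc1ccc(/C=C/C(=O)c2ccc(NC(=O)CBr)cc2)cc1`: 46%

In a functional assay on the whole organism (strain albino) for inhibition, with Rattus norvegicus as the target, read by paw edema, with stated times of 30 min and 3 h, at a dose of 100 mg/kg by the oral route (on this read-out higher numbers stand for more inhibition at the one dose given (going by the name of the read-out) and lower numbers for less inhibition), compound 1 gives 59%, the highest of the two numbers recorded. Compound 2 gives 46%. Among the compounds with values here, the only measured step, a number 13 percentage points lower from compound 1 to compound 2 (beyond the scatter), comes from a methoxy in place of chloro on an aromatic carbon, a change on the far side of the shared core from the bromoacetyl chain.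

Compound 3 `CC(Br)C(=O)Nc1ccc(C(=O)/C=C/c2ccc(Cl)cc2)cc1` differs from compound 1 by methyl in place of hydrogen on a saturated chain carbon bound to a bromine atom and a carbonyl carbon. Within the data shown here, no measured step concerns this chain, so the two numbers in hand give no direct guide to it. The change is one carbon on a saturated chain carbon bound to a bromine atom and a carbonyl carbon, and nothing measured suggests a large effect. The step of a number 4 percentage points lower from compound 1 to compound 3 (within the scatter) is therefore expected to stay within the usual scatter. For compound 3 the estimate is 55%, with a range from 35% to 72%.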

Compound 3, a percentage reported as inhibition, in the whole organism at one dose (the size of the read-out at that dose, not a potency): 59%
For compound 3 the middle estimate is 4 percentage points below the measured one; the measured number falls inside the stated range.
By their numbers in this assay, from the lowest: compound 2; then compounds 1 and 3 (each within the scatter of the next).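

In this assay, the saturated chain carbon bound to a bromine atom and a carbonyl carbon takes a methyl in place of hydrogen with no change at the digits printed from compound 1 to compound 3 (within the scatter) at the one dose given. Within the data shown here, the earlier pair differed only on an aromatic carbon carrying chloro or methoxy, so this is the first reading on the chain itself. At this dose, bromomethyl and 1-bromoethyl cannot be told apart by their numbers.

Still open, on these data alone, is whether an isopropyl or a phenyl at this same carbon, or an amine in place of the bromine, would keep the number, and whether the 1-bromoethyl chain would read the same with methoxy in place of chloro. No measurement at hand gives a reason for the matching numbers.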